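Chloro Added on the Fluorobenzyl Arm: Compound 3

The compounds below may be only part of what the source reports. "The series", "measured", "known", "first", "only" and "open" are said of these compounds alone.

Of the compounds shown here, two have so far been measured in an assay on HEK293 cells for displacement of a labelled ligand from Orexin receptor type 2 (Homo sapiens), read by scintillation counting, with a stated time of 90 min; on this read-out lower numbers stand for stronger inhibition and higher numbers for weaker inhibition. Compound 1 `COc1ccc(N2C(=O)N(Cc3ccc(F)cc3Cl)c3ccccc3S2(=O)=O)cc1OC` gives 25.1 nM, and compound 2 `COc1ccc(N2C(=O)N(Cc3ccccc3F)c3ccccc3S2(=O)=O)cc1OC` gives 6.31 nM. Among the compounds with values here, compound 2 thus stands lowest of the two numbers; its only neighbour is compound 1, with the higher number. Within the data shown here, the single measured step is a 4.0-fold lower number from compound 1 to compound 2 (0.60 log units; beyond the scatter), in which 2-fluorophenyl replaced 2-chloro-4-fluorophenyl on the saturated chain carbon bound to the amide-type nitrogen in the ring.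

Compound 3 `COc1ccc(N2C(=O)N(Cc3c(F)cccc3Cl)c3ccccc3S2(=O)=O)cc1OC` is not yet measured. It differs from compound 2 by chloro in place of hydrogen on an aromatic carbon; read one bond further out, the change is 2-fluorobenzyl to 2-chloro-6-fluorobenzyl. Among the measured compounds shown here, no measured step adds a lone chloro at this place. The step from compound 1 to compound 2 bears on it only loosely: that step removed a chloro from the same ring while also moving the fluoro, and it was modest. The expected step is a 1.9-fold higher number from compound 2 to compound 3 (0.28 log units; within the scatter), a somewhat higher number, around the edge of the scatter. For compound 3 in this assay the estimate is 12 nM, with a range from 3 nM to 50 nM.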

Compound 3, inhibition constant: 0.794 nM
Compound 3: the middle estimate sits 15-fold (1.18 log units) above what was measured; measured number below the stated range.
By their numbers in this assay, from the lowest: compound 3; then compound 2; then compound 1.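

Read in this assay, chloro in place of hydrogen on this aromatic carbon, ortho to a large group and meta to a fluoro group, gives a 7.9-fold lower number from compound 2 to compound 3 (0.90 log units; beyond the scatter) and is the first lone chloro step at this place, so a chloro on this ring can go with a lower number. The earlier step from compound 1 to compound 2 removed a chloro and moved the fluoro, and its lower number could have suggested that a chloro on this ring costs binding; the arm of compound 3 carries a chloro and still gives the lowest number of the three. With the chloro kept, the change from 2-chloro-4-fluorophenyl to 2-chloro-6-fluorophenyl gives a 32-fold lower number from compound 1 to compound 3 (1.50 log units; beyond the scatter), a large step that shows the number depends strongly on where the fluoro stands in this pair, though nothing on hand gives a reason for either step.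

The compounds shown leave open whether the lower number belongs to chloro as such or would also come with bromo or a methyl group on the same carbon. They also leave open how much the fluoro contributes, which a 2-chlorobenzyl arm on the same core would separate from the chloro.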